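The source may report more compounds than this note shows. Statements on the series, on what has been measured and on what is new or still open speak of the compounds shown alone.

Working notes on the series.

Compound 1 `O=C(Nc1cc2cc[nH]c(=O)c2cc1Cl)C1CNCCC1c1ccccc1` carries a phenyl group on the saturated amine ring attached to the shared core; in a functional assay on aorta (Rattus norvegicus) for inhibition (a higher number here means a weaker inhibitor, a lower number a stronger inhibitor), compound 1 gives 55 nM. Compound 3 `O=C(Nc1cc2cc[nH]c(=O)c2cc1Cl)[C@@H]1CCCNC1` lacks that phenyl group, and in this assay compound 3 gives 550 nM. Compound 2 `CC(C)c1cccc(C2CNCC2C(=O)Nc2cc3cc[nH]c(=O)c3cc2Cl)c1` gives in this assay only "not determined" (no result reported); on the numbers shown it stands nowhere, so no measured step into or out of it exists.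

Compound 4 `O=C(Nc1cc2cc[nH]c(=O)c2cc1Cl)C1CNCC1c1ccccc1` is derived from compound 2 by the change (hydrogen in place of isopropyl on an aromatic carbon). With no number for compound 2, neither the size nor the direction of the step from compound 2 to compound 4 in this assay can be anchored; the bare expectation is a step no larger than the scatter, in either direction.

The expectation for compound 4 rests instead on compound 1, the closest measured neighbour bearing the same phenyl group, which gives 55 nM. For compound 4 in this assay a value of about 80 nM is estimated, expected to fall between 25 nM and 250 nM.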

Compound 4, half-maximal inhibitory concentration: 89 nM
Compound 4: the middle estimate sits 1.1-fold (0.05 log units) below what was measured, within the range that was stated.
By their numbers in this assay, from the lowest: compounds 1 and 4 (each within the scatter of the next); then compound 3.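

In this assay, within the data shown here, compound 2 has no number, so no step from compound 2 to compound 4 can be read. No measurement shown accounts for the value of compound 4. The compounds shown leave open how 3-isopropylphenyl compares with phenyl on the shared core.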